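The compounds below may be only part of what the source reports. "The series", "measured", "known", "first", "only" and "open" are said of these compounds alone.

Of the compounds shown here, three built on a shared core have been tested in an assay on cells with melanin-concentrating hormone receptor 1 (Homo sapiens) as the target, read by radioligand binding; a lower number here means a stronger inhibitor, a higher number a weaker inhibitor. Compound 1 `Nc1ccc2cccc(OCC3CC4CCC3C4)c2n1` gives 137 nM, compound 3 `CNc1ccc2cccc(OC(C)CC(C)(C)C)c2n1` gives 310 nM, and compound 2 `CCCCOc1cccc2ccc(N)nc12` gives 789 nM. Compound 2 thus carries the highest number of the three: compound 3 stands below it, and compound 1 further below still, both gaps beyond the scatter. Compound 4 `CCOCC(C)Oc1cccc2ccc(N)nc12` has not yet been measured in this assay. It differs from compound 2 in one place: a group of 6 heavy atoms (5 carbon, 1 oxygen; no ring) in place of a group of 4 heavy atoms (4 carbon; no ring), on an oxygen on an aromatic ring. Within the data shown here, no measured pair shows this change, so the expectation rests loosely on the numbers; a small step toward a lower number, a 1.6-fold lower number from compound 2 to compound 4 (0.20 log units; within the scatter), is expected, hardly beyond the scatter. Compound 4 is estimated at 500 nM, within 150 nM to 1600 nM.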

Compound 4, half-maximal inhibitory concentration: 1070 nM
Compound 4: the middle estimate sits 2.1-fold (0.33 log units) below what was measured; measured number inside the range.
By their numbers in this assay, from the lowest: compound 1; then compound 3; then compounds 2 and 4 (each within the scatter of the next).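

Putting a chain of 6 heavy atoms with 1 hydrogen-bond acceptor in place of butyl, on this oxygen on an aromatic ring, gives a 1.4-fold higher number from compound 2 to compound 4 (0.13 log units; within the scatter) in this assay and so leaves the two compounds indistinguishable. This position therefore tolerates an oxygen within the chain, but that oxygen brings no gain this assay can resolve. Nothing shown explains why.

Still open, going by these compounds, is whether an amine or a carboxylic acid at the end of this chain would shift the number beyond the scatter. A longer all-carbon chain on the same oxygen also remains untested among the compounds shown.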